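The source may report more compounds than this note shows. Statements on the series, on what has been measured and on what is new or still open speak of the compounds shown alone.

Compound 1 `CNC(=O)CCCCCCCn1nc(-c2ccc3oc(N)nc3c2)c2c(N)ncnc21` was tested in a functional assay on A549 cells (Homo sapiens) for inhibition, read by MTT assay, with a stated time of 72 h (a lower number here means a stronger inhibitor, a higher number a weaker inhibitor), and gave 8360 nM. For the measured compounds named here, that is the only firm number in this small set; the other entry is not a number at all. Compound 2 `Nc1ncnc2c1c(-c1cnc3[nH]ccc3c1)nn2CCCC(=O)NO` in this assay gave > 150000 nM, which is a limit of the assay rather than a measured value (the limit of > 150000 nM in this assay, at which 1 of the 2 values shown sits). So compound 1 stands as the one compound here with a real reading, and the other compound offers no number to compare it against.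

Compound 3 `Nc1nc2cc(-c3nn(CCCCCC(=O)NO)c4ncnc(N)c34)ccc2o1` has not yet been measured in this assay. It keeps the core of compound 1 and differs from it in a single place: hydroxycarbamoyl in place of 2-(methylcarbamoyl)ethyl on a saturated chain carbon, five bonds along the chain from an aromatic nitrogen. Going by the values given here, no pair of measured compounds isolates this change, so its effect is unknown from the data. With compound 2 sitting at the limit (the limit of > 150000 nM in this assay, at which 1 of the 2 values shown sits), caution is warranted. The expected step of a 1.8-fold higher number from compound 1 to compound 3 (0.25 log units; within the scatter) is a modest loss, close to the edge of the usual scatter. Compound 3 is estimated to give 15000 nM, with a likely range from 3000 nM to 80000 nM.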

Compound 3, half-maximal inhibitory concentration: > 100000 nM
Compound 3: no number, only a limit; the forecaster's own chance of this, stated with the estimate: 15%; middle value at least 6.6-fold (0.82 log units) away from the limit.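

In this assay compound 3 gives > 100000 nM, which is a limit of the assay and not a measured number. Even so, the change of 2-(methylcarbamoyl)ethyl to hydroxycarbamoyl, on a saturated chain carbon, five bonds along the chain from an aromatic nitrogen, now has a readable effect for the first time, an at least 11-fold higher number from compound 1 to compound 3 (1.07 log units; beyond the scatter), so this end of the chain clearly matters in this assay. This step is only a minimum, and its true size stays hidden where the readings stop: the limit of > 100000 nM in this assay, at which 1 of the 3 values shown sits.

Cut further out, the same difference reads 5-(methylcarbamoyl)pentyl to 3-(hydroxycarbamoyl)propyl, so the end group and the chain length change together, and these compounds cannot show which of the two accounts for the loss. Hydroxycarbamoyl on the longer chain of compound 1, or methylcarbamoyl on the shorter chain of compound 3, would pull the two apart, and a carboxylic acid at the chain end would show whether the effect is specific to hydroxycarbamoyl.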